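The source may report more compounds than this note shows. Statements on the series, on what has been measured and on what is new or still open speak of the compounds shown alone.

Working notes on the series.

Among the measured compounds shown here, compound 3 `c1ccc(Cn2nnc3c(NC4CCCC4)nc(-c4ccccc4)nc32)cc1` stands with compound 1 `c1ccc(Cn2nnc3c(NC4CC4)nc(-c4ccccc4)nc32)cc1` at the low end of the three numbers so far in an assay on isolated protein for binding affinity to adenosine receptor A1 (Bos taurus); on this read-out lower numbers stand for stronger inhibition and higher numbers for weaker inhibition: compound 3 gives 11000000 nM, and compound 1 gives 11000000 nM, with no change at the digits printed from compound 1 to compound 3 (within the scatter). The remaining measured compound, compound 2 `CNc1nc(-c2ccccc2)nc2c1nnn2Cc1ccccc1`, gives 353000000 nM, which sits apart: a 32-fold higher number from compound 1 to compound 2 (1.51 log units; beyond the scatter) and a 32-fold lower number from compound 2 to compound 3 (1.51 log units; beyond the scatter). Within these three the only thing that moved the number was the switch between methyl and a cycloalkyl on the ring nitrogen; going from cyclopropyl to cyclopentyl did nothing beyond the scatter.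

The next compound, compound 4 `OC1CCC(Nc2nc(-c3ccccc3)nc3c2nnn3Cc2ccccc2)CC1`, differs from compound 3 as follows: 4-hydroxycyclohexyl in place of cyclopentyl on a nitrogen on an aromatic ring. For the measured compounds named here, the steps that bear on it are the ring-size comparisons: the cyclopropyl-to-cyclopentyl step was flat, and the methyl-to-cyclopentyl step was large. A six-membered ring stays on the cycloalkyl side of that divide, so a large move is not expected. Going by the values given here, the hydroxyl has no precedent in the set, so its effect is unknown and widens the range. The step from compound 3 to compound 4 is therefore expected to be a 1.1-fold higher number from compound 3 to compound 4 (0.04 log units; within the scatter), essentially none beyond the scatter. Compound 4 is estimated at 12000000 nM, within 3000000 nM to 50000000 nM.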

Compound 4, inhibition constant: 2700000 nM
Compound 4: middle estimate off by 4.4-fold (0.65 log units), on the high side; the measured number lies below the stated range.
By their numbers in this assay, from the lowest: compound 4; then compounds 1 and 3 (each within the scatter of the next); then compound 2.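

In this assay the 4-hydroxycyclohexyl group gives the lowest of the four numbers, and its substitution on the ring nitrogen shows that this position can still respond once a cycloalkyl group is present: there is a 4.1-fold lower number from compound 3 to compound 4 (0.61 log units; beyond the scatter) and likewise a 4.1-fold lower number from compound 1 to compound 4 (0.61 log units; beyond the scatter), whereas the earlier cycloalkyl comparison gave no change at the digits printed from compound 1 to compound 3 (within the scatter). Against the methyl compound the span of the series widens to a 130-fold lower number from compound 2 to compound 4 (2.12 log units; beyond the scatter), so the position now shows a clear difference among ring-bearing groups as well as the earlier one between methyl and cycloalkyl. The change enlarges the ring and adds the hydroxyl in a single step, and no measurement here explains the lower number.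

From the compounds shown here alone, whether cyclohexyl without the hydroxyl would stand level with compound 3 or with compound 4 stays open, as does whether a methoxy group, an amine or a carboxylic acid in place of the hydroxyl would keep the step. Going by these compounds, all four compounds share the rest of the core, so it also stays open whether the same step would appear on a different core.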